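The compounds below may be only part of what the source reports. "The series", "measured", "known", "first", "only" and "open" are said of these compounds alone.

In an ADME assay on the whole organism (strain 129/SvEvBrd x C57BL/6) for metabolic stability, with Mus musculus as the target (on this read-out higher numbers stand for a longer-lived compound and lower numbers for a shorter-lived compound), compound 3 `CC(O)c1nc([C@@H](O)[C@H](O)[C@H](O)CO)c[nH]1` gives 4.4 h. This is within the scatter of compound 1 `CC(=O)c1nc([C@@H](O)[C@H](O)[C@H](O)CO)c(C)[nH]1` at 6.2 h and higher than compound 2 `CC(=O)c1nc([C@@H](O)[C@H](O)[C@H](O)CO)c(-c2ccccc2)[nH]1` at 1.9 h.

Compound 4 `Cc1nc(-c2nc([C@@H](O)[C@H](O)[C@H](O)CO)c[nH]2)cs1` is the next compound to read against compound 3. The change is 2-methyl-1,3-thiazol-4-yl in place of 1-hydroxyethyl on an aromatic carbon, between two ring nitrogen atoms: 2-methyl-1,3-thiazol-4-yl in place of 1-hydroxyethyl on an aromatic carbon.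

For the measured compounds named here, no measured step replaces 1-hydroxyethyl, so the evidence is indirect. Going by the values given here, the only measured step in which an aromatic ring enters is a 3.3-fold lower number from compound 1 to compound 2 (0.51 log units; beyond the scatter), with phenyl in place of methyl on an aromatic carbon. That step is modest but beyond the scatter. It is a different replacement, so it suggests a direction more than a size. A modest downward step in this assay is therefore expected, though one within the scatter cannot be excluded. The expected change is a 1.8-fold lower number from compound 3 to compound 4 (0.25 log units; within the scatter). For compound 4 the estimate is 2.5 h, with an expected range of 1 h to 6 h.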

Compound 4, half-life: 2.1 h
Compound 4: the middle estimate sits 1.2-fold (0.08 log units) above what was measured; measured number inside the range.
By their numbers in this assay, from the lowest: compounds 2 and 4 (each within the scatter of the next); then compounds 3 and 1 (each within the scatter of the next).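

For the compounds shown here, at the aromatic carbon between two ring nitrogen atoms, 2-methyl-1,3-thiazol-4-yl in place of 1-hydroxyethyl gives a 2.1-fold lower number from compound 3 to compound 4 (0.32 log units; beyond the scatter) in this assay, the first measured change at this position and one beyond the scatter. Together with a 3.3-fold lower number from compound 1 to compound 2 (0.51 log units; beyond the scatter), at another aromatic carbon, it makes two steps in which an aromatic ring enters and the number falls, though each involves a different replacement at a different place. No measurement at hand accounts for the fall at this position.

The compounds shown do not separate what the entering 2-methyl-1,3-thiazol-4-yl contributes from what the leaving 1-hydroxyethyl contributes. A primary amine or a pyridine ring at this carbon, on the core of compound 3, would show whether the fall holds for other groups.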